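Cyclopropylmethyl on the imidazole nitrogen of a melanocortin 4 ligand

The source may hold more compounds than are shown below. What is called first, only, known or untested is meant among the compounds shown, and "the series" means these compounds.

Measured compounds:
compound 1, `COc1ccc(Br)cc1CCc1c(Cl)cccc1-c1nccn1C`: 300 nM
compound 2, `CCn1ccnc1-c1cccc(Cl)c1CCc1cc(Br)ccc1OC`: 310 nM
compound 3, `COc1ccc(Br)cc1CCc1c(Cl)cccc1-c1nccn1C(C)C`: 670 nM

Three compounds share one core and differ only in the group on the aromatic nitrogen of the imidazole ring. In an assay on isolated protein for binding affinity to Melanocortin receptor 4 (Homo sapiens) (a lower number here means a stronger inhibitor, a higher number a weaker inhibitor), compound 1 gives 300 nM, compound 2 gives 310 nM and compound 3 gives 670 nM. Compound 3 has the highest number of the three: the step of a 2.2-fold higher number from compound 1 to compound 3 (0.35 log units; beyond the scatter) and the step of a 2.2-fold higher number from compound 2 to compound 3 (0.33 log units; beyond the scatter) both lie beyond the scatter, while the step of a 1.0-fold higher number from compound 1 to compound 2 (0.01 log units; within the scatter) is within it.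

Compound 4, `COc1ccc(Br)cc1CCc1c(Cl)cccc1-c1nccn1CC1CC1`, is not yet measured. The change from compound 3 is cyclopropylmethyl in place of isopropyl on an aromatic nitrogen. Within the data shown here, no measured step introduces a ring, so the bearing is indirect: the step of a 1.0-fold higher number from compound 1 to compound 2 (0.01 log units; within the scatter) shows that adding to the chain by itself changed little, and the steps to compound 3 show that a branched group raised the number. Cyclopropylmethyl carries its ring one bond away from the nitrogen, so the expectation for compound 4 is a number near that of compound 3 or somewhat lower, the step of a 1.3-fold lower number from compound 3 to compound 4 (0.13 log units; within the scatter) expected to stay roughly within the scatter. The estimate for compound 4 in this assay is 500 nM, with a range from 250 nM to 1100 nM.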

Compound 4, inhibition constant: 2000 nM
Compound 4: middle estimate off by 4.0-fold (0.60 log units), on the low side; measured number outside the range, above it.
By their numbers in this assay, from the lowest: compounds 1 and 2 (each within the scatter of the next); then compound 3; then compound 4.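

In this assay, cyclopropylmethyl on the aromatic nitrogen gives the highest number of the series, with a 3.0-fold higher number from compound 3 to compound 4 (0.47 log units; beyond the scatter), a 6.5-fold higher number from compound 2 to compound 4 (0.81 log units; beyond the scatter) and a 6.7-fold higher number from compound 1 to compound 4 (0.82 log units; beyond the scatter). The position is therefore less forgiving than the indistinguishable values of compound 1 and compound 2 had suggested, and the number can rise well beyond the level reached with isopropyl. Branching on the carbon bound to the nitrogen is also not needed for such a rise, since that carbon in cyclopropylmethyl carries only the ring. The data shown offer no explanation for this rise.

On these data alone, it remains open whether the rise follows from the three-membered ring itself or from the extended group as a whole. An isobutyl or n-butyl chain, or a cyclopropyl group directly on the nitrogen, would separate these readings.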